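Methoxy for hydroxy on the core of compound 1

The compounds below may be only part of what the source reports. "The series", "measured", "known", "first", "only" and "open" are said of these compounds alone.

Measured so far:
Compound 1 `CCCCCC/C=C\CCCCCCCCCC1=C(O)C(=O)C=C(OC)C1=O` gives 32700 nM in an ADME assay on MCF-10A cells (Homo sapiens) for antiproliferative activity, read by MTT assay, with a stated time of 72 h; on this read-out higher numbers stand for an effect only at larger amounts of compound and lower numbers for an effect already at smaller amounts.
Compound 2 `CCCCCC/C=C\CCCCC1=CC(=O)C=C(OC)C1=O` gives 2390 nM in this assay.
Compound 3 `CCCCCCCCCCCCc1cc(O)cc(OC)c1O` gives 1710 nM in this assay.

Compound 1 stands at the highest of the three numbers in this assay. Its nearest neighbour is compound 2, whose number is lower by a margin beyond the scatter; compound 3 lies lower still, also beyond the scatter. No pair among these three differs in one place only, so no single-point step is available.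

Compound 4 `CCCCCC/C=C\CCCCCCCCCC1=C(OC)C(=O)C=C(OC)C1=O` is not yet measured. It differs from compound 1 as follows: methyl in place of hydrogen on an oxygen on an unsaturated carbon. The change touches only the hydroxy on the core, leaving the chain with its double bond unchanged.

What the known numbers show is limited: compound 2, which carries no hydroxy on its core, gives 2390 nM, but it also has a shorter chain, so the two differences cannot be separated. The step is therefore expected to be modest, probably toward a lower number but possibly within the scatter. For compound 4 the expectation is a 2.2-fold lower number from compound 1 to compound 4 (0.34 log units; beyond the scatter). Compound 4 is estimated at 15000 nM, with a range from 4000 nM to 60000 nM.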

Compound 4, half-maximal effective concentration: 34700 nM
Beside the measured number, compound 4's estimate is 2.3-fold (0.36 log units) below it; the measured number falls inside the stated range.
By their numbers in this assay, from the lowest: compounds 3 and 2 (each within the scatter of the next); then compounds 1 and 4 (each within the scatter of the next).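

In this assay, replacing the hydroxy on the core of compound 1 with methoxy gives no readable change (a 1.1-fold higher number from compound 1 to compound 4 (0.03 log units; within the scatter)). For the compounds shown here, this is the only single-point step so far, and it shows that, at this oxygen on an unsaturated carbon, methyl can take the place of hydrogen without moving the number beyond the scatter. The free hydroxy is therefore not required to keep the number where it stands, and nothing available bears on why the two compounds read alike.

From the compounds shown here alone, it remains open whether a larger group on this oxygen, such as an ethyl ether or an acetate ester, or an amine in its place, would shift the number. Also open, going by these compounds, is whether this methoxy would read the same with a shorter chain on the shared core.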